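Chloro Substitution Repeated on a Second Side Chain

The source may hold more compounds than are shown below. What is called first, only, known or untested is meant among the compounds shown, and "the series" means these compounds.

Compound 1 `Nc1nc(NCc2ccc(Oc3ccccc3)cc2)nc(-c2ccccc2CO)n1` and compound 2 `Nc1nc(NCCCc2ccccc2)nc(-c2ccccc2CO)n1` have different cores, and the difference between the two cores is not broken down here. In a functional assay on cells for positive allosteric modulation of G-protein coupled receptor 68 (Homo sapiens), read by a luciferase reporter and cAMP accumulation, with a stated time of 30 min, at pH 6.8 and pH 8.3, in the presence of a further agent that is not named here (a lower number here means a less potent compound, a higher number a more potent compound, by a factor of ten per unit of this negative logarithm), compound 1 gives 5.19, and compound 2 gives 5.22, two numbers that sit within the usual scatter of each other. Compound 3 `Nc1nc(NCCCc2ccccc2)nc(-c2cc(Cl)ccc2CO)n1` differs from compound 2 by chloro in place of hydrogen on an aromatic carbon, and in this assay compound 3 gives 5.35, which is a step of a number 0.13 log units higher from compound 2 to compound 3 (within the scatter).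

Compound 4 `Nc1nc(NCc2ccc(Oc3ccccc3)cc2)nc(-c2cc(Cl)ccc2CO)n1`, not yet measured, differs from compound 1 by chloro in place of hydrogen on an aromatic carbon, the same change as the one from compound 2 to compound 3; among the compounds shown it occurs twice in all. For compound 4 the step is expected to be a number 0.13 log units higher from compound 1 to compound 4 (within the scatter), resting on the earlier step of a number 0.13 log units higher from compound 2 to compound 3 (within the scatter), which stayed within the scatter. Compound 4 is therefore estimated to give 5.32 in this assay, expected to fall between 4.95 and 5.7.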

Compound 4, negative logarithm of the antagonist equilibrium constant: 4.7
Compound 4: the middle estimate sits 0.62 log units above what was measured; measured number outside the range, below it.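

The same change does not carry over unchanged between these two cores. On the second core, chloro in place of hydrogen on the aromatic carbon para to a hydroxymethyl group gives a step of a number 0.49 log units lower from compound 1 to compound 4 (beyond the scatter), whereas the earlier step stayed within the scatter, and the two cannot be treated as one transferable increment in this assay: the same change on two cores in this assay, a number 0.13 log units higher (within the scatter) from compound 2 to compound 3 and a number 0.49 log units lower (beyond the scatter) from compound 1 to compound 4, 0.62 log units apart, beyond the scatter of two such steps What this shows is limited to these two pairs of compounds, so it establishes that the step differs with the core here, but it does not show which part of the cores accounts for the difference, nor how the change would behave on any third core.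

The compounds shown leave open whether fluoro, bromo or methyl at the same place would split between the two cores as chloro does. They also leave open how the chloro step would run on a core carrying a longer chain or an amine on its side chain.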